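A few compounds are considered here, and "the series" means these few. Any claim that something is new, unique, unknown or untested is made for them only; others in the source may bear on it.

In a functional assay on A549 cells (Homo sapiens) for inhibition, read by CCK-8 assay, with a stated time of 48 h (on this read-out lower numbers stand for stronger inhibition and higher numbers for weaker inhibition), compound 1 (`COc1cc(-c2cc3nccc(-c4cc(OC)c(OC)c(OC)c4)n3n2)cc(OC)c1OC`) gives > 10000 nM, which is a limit of the assay and not a number. Compound 2 (`COc1cc(-c2ccnc3cc(-c4ccc(F)cc4)nn23)cc(OC)c1OC`) gives 3800 nM in this assay, and compound 3 (`COc1cc(-c2ccnc3cc(-c4ccc(Cl)cc4)nn23)cc(OC)c1OC`) gives 3070 nM in the same test. Going by the values given here, these are the only two numbers available, and compound 2 stands level with compound 3: the step between them is a 1.2-fold lower number from compound 2 to compound 3 (0.09 log units; within the scatter). Compound 4 (`COc1cc(-c2ccnc3cc(-c4ccc(C)cc4)nn23)cc(OC)c1OC`) has methyl in place of fluoro on an aromatic carbon, para to a large group (methyl in place of fluoro on an aromatic carbon). Among the compounds with values here, one measured step bears on this change, the replacement of fluoro by chloro at that same carbon, and it amounts to a 1.2-fold lower number from compound 2 to compound 3 (0.09 log units; within the scatter). Within the data shown here, with only that small step as a guide, no step beyond the scatter is expected in this assay, and no direction can be favoured. The expected step is a 1.1-fold lower number from compound 2 to compound 4 (0.04 log units; within the scatter). The estimated value for compound 4 is 3500 nM, with an expected range from 1800 nM to 7000 nM.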

Compound 4, half-maximal inhibitory concentration: 3 nM
Beside the measured number, compound 4's estimate is 1200-fold (3.07 log units) above it, outside the stated range (below it).
By their numbers in this assay, from the lowest: compound 4; then compounds 3 and 2 (each within the scatter of the next). At a limit, above all of these: compound 1.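

In this assay the 4-methylphenyl group stands far apart from both halogen-bearing compounds: the step of a 1300-fold lower number from compound 2 to compound 4 (3.10 log units; beyond the scatter) and the step of a 1000-fold lower number from compound 3 to compound 4 (3.01 log units; beyond the scatter) are both large. The earlier change from fluoro to chloro, a 1.2-fold lower number from compound 2 to compound 3 (0.09 log units; within the scatter), stayed within the scatter and gave no sign of this, yet this carbon, para to a large group, proves highly sensitive to what it carries, and exchanging one heavy atom is enough to move the number this far. Nothing given here accounts for the gap between methyl and the two halogens.

The compounds shown leave open whether the low number belongs to methyl alone or extends to ethyl, a longer chain or an amine at this carbon. On these data alone, whether it holds in other cell types also remains open.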